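The source may hold more compounds than are shown below. What is called first, only, known or untested is meant among the compounds shown, and "the series" means these compounds.

Within the data shown here, compound 2 `CNC(=O)CCc1cn(Cc2ccc(C(=O)NS(=O)(=O)c3ccccc3C)cc2OC)c2cc(C(=O)NCC3CCCC3)ccc12` is one of three compounds measured in a functional assay on trachea for agonist activity at cysteinyl leukotriene receptor (Homo sapiens) (a lower number here means a stronger inhibitor, a higher number a weaker inhibitor), where compound 2 gives 0.399 nM. Compound 1 `COc1cc(C(=O)NS(=O)(=O)c2ccccc2C)ccc1Cc1cn(C)c2ccc(C(=O)NCC3CCCC3)cc12` gives 4.28 nM in this assay, and compound 3 `COc1cc(C(=O)NS(=O)(=O)c2ccccc2C)ccc1Cc1cn(C)c2ccc(NC(=O)CC3CCCC3)cc12` gives 24.5 nM. Compound 2 therefore stands lowest of the three, with compound 1 nearest and compound 3 furthest away. Among the measured compounds shown here, the only single-point step among them is a 5.7-fold higher number from compound 1 to compound 3 (0.76 log units; beyond the scatter), which concerns the linkage to the cyclopentyl-bearing side chain and not the indole substituent. Compound 4 `COc1cc(C(=O)NS(=O)(=O)c2ccccc2C)ccc1Cn1cc(CC(C)C(=O)N(C)C)c2ccc(C(=O)NCC3CCCC3)cc21` differs from compound 2 by 1-(dimethylcarbamoyl)ethyl in place of (methylcarbamoyl)methyl on a saturated chain carbon bound to an aromatic carbon. For the measured compounds named here, no measured step touches this position, and compounds 1 and 2 differ in more than one place, so their two values cannot be read as a step. The expectation rests only on the closeness of compound 2 to the low end of the series: compound 4 is estimated at 0.8 nM, within 0.25 nM to 2.5 nM, which would mean an expected step of a 2.0-fold higher number from compound 2 to compound 4 (0.30 log units; within the scatter), likely inside or only just beyond the scatter.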

Compound 4, antagonist equilibrium constant: 0.65 nM
Compound 4: the middle estimate sits 1.2-fold (0.09 log units) above what was measured; low and high end bracket the measured number.
By their numbers in this assay, from the lowest: compounds 2 and 4 (each within the scatter of the next); then compound 1; then compound 3.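

In this assay, putting 1-(dimethylcarbamoyl)ethyl in place of (methylcarbamoyl)methyl on a saturated chain carbon bound to an aromatic carbon gives a 1.6-fold higher number from compound 2 to compound 4 (0.21 log units; within the scatter). Among these compounds, this is the first measured change at this position, and it shows that the position accepts a group of 7 heavy atoms instead of 5, with 0 hydrogen-bond donors instead of 1, without a step that stands out from the scatter. No measurement at hand bears on why the two groups read alike.

The change alters the chain and the amide nitrogen together, so the compounds shown do not separate the contribution of either part. Going by these compounds, how a carboxylic acid or a primary amine at the end of this chain would read also stays open.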